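Chlorophenyl Replaces Thiophene on the Shared Core

The compounds below may be only part of what the source reports. "The series", "measured", "known", "first", "only" and "open" are said of these compounds alone.

Compound 3 `CCOC(=O)c1c(C)[nH]c(=O)c(C#N)c1-c1cccs1` is one of three compounds tested in a functional assay on aorta (Rattus norvegicus) for inhibition; on this read-out higher numbers stand for larger maximal responses and lower numbers for smaller maximal responses. In this assay compound 3 gives 100%, level with compound 1 `CCOC(=O)c1c(C)[nH]c(=O)c(C#N)c1-c1ccco1`, which gives 100%; compound 2 `CCOC(=O)c1c(C)[nH]c(=O)c(C#N)c1-c1ccc([N+](=O)[O-])cc1[N+](=O)[O-]` gives 97%, a number within the scatter of both. Among the measured compounds shown here, the only single-point step among the measured compounds, no change at the digits printed from compound 1 to compound 3 (within the scatter), put thiophen-2-yl in place of furan-2-yl without moving the read-out. Compound 4 `CCOC(=O)c1c(C)[nH]c(=O)c(C#N)c1-c1cccc(Cl)c1` differs from compound 3 by 3-chlorophenyl in place of thiophen-2-yl on an aromatic carbon. For the measured compounds named here, no measured step brings a six-membered aromatic ring of carbon only to this position, so the expectation rests on the three numbers alone: the step of a number 2 percentage points lower from compound 3 to compound 4 (within the scatter) is expected to stay within the scatter. Compound 4 is therefore estimated at 98%, with a range from 88% to 102%.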

Compound 4, largest response reached (reported as efficacy), in percent of the reference or control that the assay uses: 97%
Beside the measured number, compound 4's estimate is 1 percentage points above it, within the range that was stated.
By their numbers in this assay, from the lowest: compounds 2, 4, 1 and 3 (each within the scatter of the next).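

From thiophen-2-yl to 3-chlorophenyl the read-out in this assay shows a number 3 percentage points lower from compound 3 to compound 4 (within the scatter) and from furan-2-yl to 3-chlorophenyl it shows a number 3 percentage points lower from compound 1 to compound 4 (within the scatter) on the same carbon, opposite the ring nitrogen. Among the compounds shown here, these are the first single-place steps that exchange a five-membered aromatic ring with one hetero atom for a six-membered aromatic ring of carbon only, and the read-out stays within the scatter across both. On these data alone, whether an amine or a carboxylic acid on the phenyl ring, or a saturated piperidine ring at this carbon, would hold the read-out remains open. No evidence is available that bears on this result.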